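Opening a cyclic sulfonamide into a sulfopropylamino chain

The source may report more compounds than this note shows. Statements on the series, on what has been measured and on what is new or still open speak of the compounds shown alone.

Compound 1 `CS(=O)(=O)c1cccc(S(=O)(=O)c2ccc3c(c2)CCC[C@H]3CN)c1`: 3.98 nM
Compound 2 `Cn1ccc(S(=O)(=O)c2ccc3c(c2)CCC[C@H]3CN)c1`: 7.94 nM
Compound 3 `O=S(=O)(c1cccc(F)c1)c1ccc2c(c1)CCC[C@H]2CN1CCCS1(=O)=O`: 31.6 nM

Of the compounds shown here, three built on a shared core have been measured in an assay on isolated protein for displacement of a labelled ligand from 5-hydroxytryptamine receptor 6 (Homo sapiens); a higher number here means a weaker inhibitor, a lower number a stronger inhibitor. Compound 1 gives 3.98 nM in this assay, and compound 2 gives 7.94 nM. Compound 3 stands at the top of the three numbers with 31.6 nM; its nearest neighbour is compound 2, which lies beyond the scatter below it, and compound 1 lies further below still. Compound 3 carries the weakest inhibition among the three measured compounds.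

Compound 4 `O=S(=O)(O)CCCNC[C@@H]1CCCc2cc(S(=O)(=O)c3cccc(F)c3)ccc21` has not yet been measured. It differs from compound 3 in one place: a group of 8 heavy atoms (3 carbon, 1 nitrogen, 3 oxygen, 1 sulfur; no ring) in place of a group of 7 heavy atoms (3 carbon, 1 nitrogen, 2 oxygen, 1 sulfur; one five-membered non-aromatic ring with 2 hetero atoms), on a saturated chain carbon bound to a saturated ring carbon. In compound 4 the (3-sulfopropyl)amino group brings two hydrogen-bond donors where the departing group in compound 3 brought none.

Among the measured compounds shown here, no step between measured compounds covers this kind of change, so any expectation rests on the three values alone. For the measured compounds named here, compound 3 is the only compound with a substituted amine, and both unsubstituted analogues, compound 1 and compound 2, give lower numbers. Compound 4 is therefore expected to move in the direction of those lower numbers, by a step of a 2.1-fold lower number from compound 3 to compound 4 (0.32 log units; beyond the scatter), which may or may not exceed the scatter. For compound 4 the estimate is 15 nM, with a range from 3 nM to 80 nM.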

Compound 4, inhibition constant: 1.26 nM
Compound 4: the middle estimate sits 12-fold (1.08 log units) above what was measured; the measured number lies below the stated range.
By their numbers in this assay, from the lowest: compound 4; then compounds 1 and 2 (each within the scatter of the next); then compound 3.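

In this assay, replacing the five-membered ring group of compound 3 with the open (3-sulfopropyl)amino group, on a saturated chain carbon bound to a saturated ring carbon, gives a large change: a 25-fold lower number from compound 3 to compound 4 (1.40 log units; beyond the scatter). Compound 4, at 1.26 nM, shows that a substituent at this place need not come with a higher number, and that the value here depends strongly on which group is attached. Nothing measured here explains why the step is so large.

This single step changes several things at once, as the ring opens and the sulfo group appears on the chain, so the compounds shown cannot say which of these changes accounts for the lower number. They also leave open whether a carboxylic acid or a hydroxyl group at the end of the propyl chain, a shorter or longer chain, or a plain alkylamine would give a similar value, and whether the same group would do so on the core of compound 1 or compound 2, with their different sulfonyl substituents.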